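A few compounds are considered here, and "the series" means these few. Any claim that something is new, unique, unknown or untested is made for them only; others in the source may bear on it.

Working notes, aryl variation on the shared core.

Three compounds carry a number or a call in a functional assay on CCRF-CEM cells (Homo sapiens) for inhibition; a lower number here means a stronger inhibitor, a higher number a weaker inhibitor. Compound 1 `Cc1csc(-c2ncnc3c2ncn3C2O[C@H](CO)[C@@H](O)[C@H]2O)n1` gives 6000 nM. Compound 2 `Cc1cc(-c2ncnc3c2ncn3C2O[C@H](CO)[C@@H](O)[C@H]2O)on1` is reported as "not active" (no number reported), with no number behind it. Compound 3 `OC[C@H]1OC(n2cnc3c(-c4ccccn4)ncnc32)[C@H](O)[C@@H]1O` gives 900 nM, the lowest of the two numbers; the nearest is compound 1, and the step of a 6.7-fold lower number from compound 1 to compound 3 (0.82 log units; beyond the scatter) sets compound 3 apart from it beyond the scatter.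

The next entry, compound 4 `OC[C@H]1OC(n2cnc3c(-c4ccc(O)cc4)ncnc32)[C@H](O)[C@@H]1O`, is not yet measured in this assay. It differs from compound 3 in one place: 4-hydroxyphenyl in place of pyridin-2-yl on an aromatic carbon. The group sits on an aromatic carbon next to the ring nitrogen of the core.

Among the compounds with values here, only one measured step touches this position, a 6.7-fold lower number from compound 1 to compound 3 (0.82 log units; beyond the scatter), and it exchanges one ring with a hetero atom for another; nothing measured shows a carbon-only ring with a hydroxyl there, and compound 2 shows such exchanges can also remove activity altogether. The expected step of a 2.0-fold higher number from compound 3 to compound 4 (0.30 log units; within the scatter) is therefore small, with a wide range and a lean toward a weaker compound 4. Compound 4 is estimated at 1800 nM, between 500 nM and 7000 nM.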

Compound 4, half-maximal inhibitory concentration: 1250 nM
Beside the measured number, compound 4's estimate is 1.4-fold (0.16 log units) above it, and the stated range covers the measured number.
By their numbers in this assay, from the lowest: compounds 3 and 4 (each within the scatter of the next); then compound 1.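

In this assay, the step of a 1.4-fold higher number from compound 3 to compound 4 (0.14 log units; within the scatter) shows that a carbon-only ring carrying a hydroxyl, 4-hydroxyphenyl, gives a number on this aromatic carbon that cannot be told apart from that of pyridin-2-yl, so a hetero atom in the ring is not needed to hold activity at this level. The step of a 4.8-fold lower number from compound 1 to compound 4 (0.68 log units; beyond the scatter) shows that 4-hydroxyphenyl, like pyridin-2-yl, stands apart from 4-methyl-1,3-thiazol-2-yl beyond the scatter, which gives this position a second, independent exchange with a lower number than compound 1. No measurement at hand offers a reason for either step.

The compounds shown leave open what the hydroxyl itself contributes, which a plain phenyl would separate from the ring. Also open, as far as these compounds go, is how an amine or a carboxylic acid in place of that hydroxyl would read in this assay.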